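The compounds below may be only part of what the source reports. "The series", "measured", "known", "first", "only" and "open" are said of these compounds alone.

Measured in an ADME assay on HEL cells (Homo sapiens) for cytotoxicity, with a stated time of 3 days; a lower number here means that less compound is tolerated, a higher number that more compound is tolerated:
- compound 1 `Cc1cn([C@@H]2O[C@H](CO[Si](C)(C)C(C)(C)C)[C@@]3(OS(=O)(=O)C=C3NC(=O)NC(=O)c3ccccc3)[C@H]2O[Si](C)(C)C(C)(C)C)c(=O)n(C)c1=O`: > 200000 nM (a limit)
- compound 2 `Cc1cn([C@@H]2O[C@H](CO[Si](C)(C)C(C)(C)C)[C@@]3(OS(=O)(=O)C=C3NC(=O)NC(=O)c3ccccc3)[C@H]2O)c(=O)n(C)c1=O`: 22000 nM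
- compound 3 `Cc1cn([C@@H]2O[C@H](CO[Si](C)(C)C(C)(C)C)[C@@]3(OS(=O)(=O)C=C3NC(=O)NC(=O)c3ccccc3)[C@H]2O[Si](C)(C)C(C)(C)C(C)C)c(=O)n(C)c1=O`: >= 100000 nM (a limit)

Compound 1 has no number of its own, only a limit, and compound 3 likewise has only a limit. Compound 4 `Cc1cn([C@@H]2O[C@H](CO[Si](C(C)C)(C(C)C)C(C)C)[C@@]3(OS(=O)(=O)C=C3NC(=O)NC(=O)c3ccccc3)[C@H]2O[Si](C)(C)C(C)(C)C)c(=O)n(C)c1=O` differs from compound 1 by a group of 10 heavy atoms (9 carbon, 1 silicon; no ring) in place of a group of 7 heavy atoms (6 carbon, 1 silicon; no ring), on an oxygen on a saturated carbon. The readable steps both concern a silicon-bearing group against a hydrogen atom: an at least 9.0-fold lower number from compound 1 to compound 2 (0.95 log units; beyond the scatter) and an at least 4.5-fold higher number from compound 2 to compound 3 (0.65 log units; beyond the scatter). The step closest in kind, enlarging such a group, is a step that the two limits leave unreadable from compound 1 to compound 3. Compound 4 keeps its silicon-bearing groups, unlike compound 2 at 22000 nM, so no fall to that level is expected. The expected change is an at least 1.3-fold lower number from compound 1 to compound 4 (0.12 log units; that floor lies within the scatter), a step not expected to exceed the scatter. For compound 4 the estimate is 150000 nM, with an expected range of 50000 nM to 300000 nM.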

Compound 4, half-maximal cytotoxic concentration: > 100000 nM
Compound 4 ended at the assay's limit (the forecaster's own chance of this, stated with the estimate: 60%); the middle value lies beyond the limit too.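

Compound 1 has only a limit, > 200000 nM. Compound 4 also has only a limit, > 100000 nM. Going by these compounds alone, no step between them can be read. As far as these compounds go, whether the group of 10 heavy atoms changes the read-out relative to the group of 7 heavy atoms stays open.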